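Replacing the 3-methylphenyl group of compound 1

The source may hold more compounds than are shown below. What is called first, only, known or untested is meant among the compounds shown, and "the series" means these compounds.

In an ADME assay on HCT-116 cells (Homo sapiens) for cytotoxicity, read by CellTiter-Glo, with a stated time of 72 h (on this read-out higher numbers stand for weaker inhibition and lower numbers for stronger inhibition), compound 1 `Cc1cccc(S(=O)(=O)N2CCC(N3CCC(C)CC3)CC2)c1` gives > 5000 nM as a limit of the assay and not a number. Compound 2 `Cc1ccc(C#N)c(S(=O)(=O)N2CCC(N3CCC(C)CC3)CC2)c1` also gives > 5000 nM as a limit. Compound 3 `CC1CCN(C2CCN(S(=O)(=O)c3cccc(-c4ccc(F)cc4)c3)CC2)CC1` likewise gives > 5000 nM as a limit. Compound 4 `Cc1nc(Cl)sc1S(=O)(=O)N1CCC(N2CCC(C)CC2)CC1` is not yet measured: 2-chloro-4-methyl-1,3-thiazol-5-yl stands in place of 3-methylphenyl on a sulfonyl sulfur 2-chloro-4-methyl-1,3-thiazol-5-yl in place of 3-methylphenyl on a sulfonyl sulfur in the shared core. The two measured changes give no size to carry over, as a step that the two limits leave unreadable from compound 1 to compound 2 and a step that the two limits leave unreadable from compound 1 to compound 3 both stay unreadable. Among the measured compounds shown here, the only guide is the limit of > 5000 nM in this assay, at which 3 of the 3 values shown sit, and nothing firmer. So a step that the limit leaves unreadable from compound 1 to compound 4 is the expected step in this assay with no direction to claim. Compound 4 is estimated at 8000 nM within a range of 4000 nM to 20000 nM and will most likely be reported only as a limit.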

Compound 4, half-maximal inhibitory concentration: > 10000 nM
Compound 4: only a limit was reported (the forecaster's own chance of this, stated with the estimate: 85%); middle value at least 1.2-fold (0.09 log units) from the limit.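

Among the compounds shown here, compound 4 gives > 10000 nM as a limit of the assay and not a number, so no step from compound 1 to compound 4 can be read. The compounds shown leave open whether any of these changes shifts cytotoxicity at all: all four values are limits.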